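Swapping a Piperazine for a Pyrazole on a Urea

The compounds below may be only part of what the source reports. "The series", "measured", "known", "first", "only" and "open" are said of these compounds alone.

Compound 1 `Cc1cc(C)c(NC(=O)N(Cc2ccc(N3CCN(C)CC3)cc2)C2CCCCCC2)c(C)c1` is a urea tested in a functional assay on a cell-free system (plasma) with sterol O-acyltransferase, Soat (Rattus norvegicus) as the target; a lower number here means that less compound is needed, a higher number that more compound is needed for the effect; there compound 1 gives > 1 mg/kg, which is a limit of the assay rather than a number. Compound 2 `CN(C)c1ccc(CN(Cc2cccc(-c3cc[nH]n3)c2)C(=O)Nc2c(F)cc(F)cc2F)cc1` gives < 0.32 mg/kg, also a limit. Compound 3 `O=C(Nc1c(F)cc(F)cc1F)N(Cc1ccc(F)cc1)Cc1cccc(-c2cc[nH]n2)c1` gives < 0.32 mg/kg, again a limit, so a step that the two limits leave unreadable from compound 2 to compound 3 cannot be read. Compound 4 `Cc1cc(C)c(NC(=O)N(Cc2ccc(-c3cc[nH]n3)cc2)C2CCCCCC2)c(C)c1` arises from compound 1 by 1H-pyrazol-3-yl in place of 4-methylpiperazin-1-yl on an aromatic carbon. For the measured compounds named here, no measured step bears directly on this change; the only pointers are that compounds 2 and 3, which carry the same 1H-pyrazol-3-yl group, sit at the limit of < 0.32 mg/kg in this assay, at which 2 of the 3 values shown sit, while compound 1 sits at the limit of > 1 mg/kg in this assay, at which 1 of the 3 values shown sits. A downward step is therefore expected, estimated as an at least 2.0-fold lower number from compound 1 to compound 4 (0.30 log units; that floor lies within the scatter). Compound 4 is expected to reach 0.5 mg/kg, within 0.15 mg/kg to 2 mg/kg.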

Compound 4, dose for half-maximal effect: > 1 mg/kg
Compound 4: only a limit was reported; the forecaster's own chance of this, stated with the estimate: 60%; middle value at least 2.0-fold (0.30 log units) from the limit.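

Compound 1 and compound 4 each give only a limit, and the step between them cannot be read. The compounds shown leave open whether 1H-pyrazol-3-yl in place of 4-methylpiperazin-1-yl changes the number in this assay at all.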